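Swapping the aryl group on a sulfonyl sulfur

The compounds below may be only part of what the source reports. "The series", "measured", "known", "first", "only" and "open" are said of these compounds alone.

For the measured compounds named here, three related compounds have numbers so far. In a functional assay on LNCaP cells (Homo sapiens) for antiproliferative activity, read by propidium iodide staining, with a stated time of 96 h (on this read-out lower numbers stand for stronger inhibition and higher numbers for weaker inhibition), compound 1 (`CC(O)(CSc1ccc(OC(F)(F)F)cc1)C(=O)Nc1ccc(S(F)(F)(F)(F)F)cc1`) gives 16100 nM, compound 2 (`CC(O)(CS(=O)(=O)c1ccc(S(F)(F)(F)(F)F)cc1)C(=O)Nc1ccc(S(F)(F)(F)(F)F)cc1`) gives 29200 nM and compound 3 (`CC(O)(CS(=O)(=O)c1ccc(F)cc1)C(=O)Nc1ccc(S(F)(F)(F)(F)F)cc1`) gives 18200 nM. Compound 3 lies within the usual scatter of both others, so it cannot be ranked against either of them.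

Compound 4 (`CC(O)(CS(=O)(=O)c1ccccc1C(F)(F)F)C(=O)Nc1ccc(S(F)(F)(F)(F)F)cc1`) has not yet been measured. It differs from compound 3 in a single place, with 2-(trifluoromethyl)phenyl in place of 4-fluorophenyl on a sulfonyl sulfur.

Going by the values given here, one measured step bears on this change, because it alters the same aryl group on the sulfonyl sulfur: a 1.6-fold lower number from compound 2 to compound 3 (0.21 log units; within the scatter). There, a single fluorine atom replaces a larger group of sulfur and fluorine on an aromatic carbon, and the step stays within the scatter. Among the compounds with values here, this is thin evidence, since it is only one step and no measured compound carries the 2-(trifluoromethyl)phenyl group. Even so, the expected change in this assay is none beyond the scatter, an estimated 1.1-fold higher number from compound 3 to compound 4 (0.04 log units; within the scatter). For compound 4 the estimated value is 20000 nM, with an expected range from 9000 nM to 42000 nM.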

Compound 4, half-maximal inhibitory concentration: 10800 nM
Beside the measured number, compound 4's estimate is 1.9-fold (0.27 log units) above it; low and high end bracket the measured number.
By their numbers in this assay, from the lowest: compounds 4, 1, 3 and 2 (each within the scatter of the next, the first and the last beyond it).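

In this assay, replacing 4-fluorophenyl on the sulfonyl sulfur with 2-(trifluoromethyl)phenyl gives a 1.7-fold lower number from compound 3 to compound 4 (0.23 log units; within the scatter), so this larger aryl group, with its 10 heavy atoms against 7, is accommodated without a step beyond the usual scatter. The new result also gives the first gap beyond the scatter in this small set: compound 4 at 10800 nM and compound 2 at 29200 nM are the two ends of the printed values, while compounds 1 and 3 fall within the scatter of their neighbours in the order. Nothing measured here explains why the number moves with the aryl group.

As far as these compounds go, whether this position needs an aryl group at all remains open, as a plain methyl group or a pyridine ring on the sulfonyl sulfur would test that directly. From the compounds shown here alone, the effect of the sulfur's oxidation state also stays open, since compound 1 differs from the sulfonyl compounds in its aryl group as well, and a matched pair carrying the same aryl group would be needed to separate the two changes.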